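Ester tail variation on the chloro-quinoline triazole series

The source may hold more compounds than are shown below. What is called first, only, known or untested is meant among the compounds shown, and "the series" means these compounds.

The set shares a chloro-substituted bicyclic core bearing a triazole; compound 1 `Clc1ccc2c(-n3cc(-c4ccccc4)nn3)ccnc2c1` carries a plain phenyl on that triazole, compound 2 `COc1ccc2cc(-c3cn(-c4ccnc5cc(Cl)ccc45)nn3)ccc2c1` a methoxy-substituted naphthyl, and compound 3 `COc1ccc(C(=O)OCCCc2cn(-c3ccnc4cc(Cl)ccc34)nn2)cc1` a three-carbon chain ending in a 4-methoxyphenyl ester. In an ADME assay on HepG2 cells (Homo sapiens) for cytotoxicity, read by MTT assay, with a stated time of 24 h (a lower number here means that less compound is tolerated, a higher number that more compound is tolerated), compound 1 gives 574000 nM and compound 3 gives 347000 nM. For compound 2 this assay reports only a limit, > 2590000 nM, not a number. Among the two numbers that are actual values, compound 3 holds the lower one, but the gap to compound 1 lies within the scatter, so the two cannot be ordered; the third entry is the limit described in the limit of > 2590000 nM in this assay, at which 1 of the 3 values shown sits.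

Compound 4 `CC(C)(C)c1ccc(C(=O)OCCCc2cn(-c3ccnc4cc(Cl)ccc34)nn2)cc1` is compound 3 with tert-butyl in place of methoxy on an aromatic carbon, so that the ester's aryl reads 4-(tert-butyl)phenyl instead of 4-methoxyphenyl. Going by the values given here, no measured pair in this set makes the same exchange, so the step has no precedent here. The expectation is that the exchange changes tolerance little, with a step from compound 3 to compound 4 in this assay of a 1.4-fold lower number from compound 3 to compound 4 (0.14 log units; within the scatter), if anything toward a slightly lower number. Compound 4 is therefore estimated in this assay at 250000 nM, expected to fall between 90000 nM and 700000 nM.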

Compound 4, half-maximal cytotoxic concentration: > 2230000 nM
Compound 4 was reported as a limit; the forecaster's own chance of this, stated with the estimate: 10%; middle value at least 8.9-fold (0.95 log units) from the limit.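

In this assay, going by these compounds alone, the aromatic carbon at the end of the ester tail is not a silent position: tert-butyl in place of methoxy there gives an at least 6.4-fold higher number from compound 3 to compound 4 (0.80 log units; beyond the scatter), the only step in the set that can be read and one beyond the scatter. Compound 4 is reported as a limit, not a number, so the step fixes a direction and a minimum size only: the limit of > 2230000 nM in this assay, at which 1 of the 4 values shown sits.
Compound 3 and compound 4 carry the same ester chain on the triazole, so in this assay that chain alone does not settle the reading, and the group on the aromatic ring of the ester counts as well.

A single exchange at this position is shown, so it stays open whether a hydrogen, a chlorine or a dimethylamino group on the same carbon would read like methoxy or like tert-butyl. Also open, going by these compounds, are how far the true reading of compound 4 lies past its limit and whether the same exchange holds with a longer chain or with an amide in place of the ester.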